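The compounds below may be only part of what the source reports. "The series", "measured", "known", "first", "only" and "open" are said of these compounds alone.

Measured compounds in a functional assay on HL-60 cells (Homo sapiens), with a stated time of 2 days; a lower number here means a stronger inhibitor, a higher number a weaker inhibitor:
- compound 1 `O=C(Nc1ccc(Cl)c(Cl)c1)c1nc[nH]c1C(=O)NCc1ccc(Cl)cc1` — 16200 nM
- compound 2 `COc1ccc(CNC(=O)c2[nH]cnc2C(=O)Nc2ccc(Cl)c(Cl)c2)cc1` — 24300 nM
- compound 3 `COC(=O)[C@@H](C)NC(=O)c1[nH]cnc1C(=O)Nc1ccc(Cl)c(Cl)c1` — > 62500 nM, a limit of the assay, not a number

Compound 1 holds the lower of the two numbers obtained, but the step of a 1.5-fold higher number from compound 1 to compound 2 (0.18 log units; within the scatter) is within the scatter, so compound 1 and compound 2 are not separated. The third value is a limit (the limit of > 62500 nM in this assay, at which 1 of the 3 values shown sits); its sentence stands alone above.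

Compound 4 `C[C@@H](NC(=O)c1[nH]cnc1C(=O)Nc1ccc(Cl)c(Cl)c1)C(=O)OC(C)(C)C` is to be measured. It differs from compound 1 by 1-(tert-butoxycarbonyl)ethyl in place of 4-chlorobenzyl on an amide-type nitrogen. The measured steps that bear on this are an at least 3.8-fold higher number from compound 1 to compound 3 (0.58 log units; beyond the scatter) and an at least 2.5-fold higher number from compound 2 to compound 3 (0.41 log units; beyond the scatter), both at least modest and both in the weakening direction when a benzyl group on that amide-type nitrogen is exchanged for a 1-(methoxycarbonyl)ethyl group. Going by the values given here, the change to compound 4 is of the same kind, with a tert-butoxycarbonyl in place of a methoxycarbonyl; no measured pair shows the effect of that ester exchange on its own.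

Accordingly a weakening step is expected, a 4.0-fold higher number from compound 1 to compound 4 (0.60 log units; beyond the scatter), and the estimate for compound 4 in this assay is 65000 nM, within 25000 nM to 170000 nM, with a real chance that only a limit is reported.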

Compound 4, half-maximal inhibitory concentration: 4600 nM
The estimate for compound 4 lay 14-fold (1.15 log units) above the measured number; measured number outside the range, below it.
By their numbers in this assay, from the lowest: compound 4; then compounds 1 and 2 (each within the scatter of the next). At a limit, above all of these: compound 3.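

In this assay the ester side chain on the amide-type nitrogen is not weak as such, and its outcome turns on the group on the ester oxygen: tert-butyl in place of methyl gives an at least 13-fold lower number from compound 3 to compound 4 (1.13 log units; beyond the scatter). Compound 3 stands at a limit of the assay, so that step is a bound and not a measured size: the limit of > 62500 nM in this assay, at which 1 of the 4 values shown sits. Against the benzyl amides, 1-(tert-butoxycarbonyl)ethyl gives a 3.5-fold lower number from compound 1 to compound 4 (0.55 log units; beyond the scatter) and a 5.3-fold lower number from compound 2 to compound 4 (0.72 log units; beyond the scatter), so in this series an aromatic ring on that nitrogen is not required for the lowest number shown.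

An ethyl or isopropyl ester would show whether the change is graded along the ester alkyl group or specific to tert-butyl. The free carboxylic acid, or the opposite configuration at the stereocentre, would show how much of the result depends on the intact ester and on its defined geometry.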